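The source may hold more compounds than are shown below. What is called first, only, known or untested is meant among the compounds shown, and "the series" means these compounds.

Compound 3 `CC(C)C(Cc1ncc[nH]1)c1ccc(-c2ccc3cccc(F)c3c2)[nH]c1=O` gives 33800 nM in a physicochemical assay for solubility, measured as kinetic solubility, at pH 2; on this read-out higher numbers stand for higher solubility and lower numbers for lower solubility. Compound 1 `CC(C)C(c1ncc[nH]1)c1ccc(-c2ccc3cccc(F)c3c2)[nH]c1=O` gives 31800 nM, and compound 2 `CC(C)C(c1ccc(-c2ccc3cccc(F)c3c2)[nH]c1=O)N1CCCCC1=O` gives 23500 nM, so all three sit together within the usual scatter of this assay, and compound 3 stands apart from neither. Going by the values given here, compound 4 `CC(C)C(c1noc(=O)[nH]1)c1ccc(-c2ccc3cccc(F)c3c2)[nH]c1=O` differs from compound 3 in one place: a group of 6 heavy atoms (2 carbon, 2 nitrogen, 2 oxygen; one five-membered aromatic ring with 3 hetero atoms) in place of a group of 6 heavy atoms (4 carbon, 2 nitrogen; one five-membered aromatic ring with 2 hetero atoms), on a saturated chain carbon bound to an aromatic carbon and a saturated chain carbon The steps that bear on this swap at the same carbon were a 1.4-fold lower number from compound 1 to compound 2 (0.13 log units; within the scatter) and a 1.4-fold higher number from compound 2 to compound 3 (0.16 log units; within the scatter), both within the scatter, so changes at this position have so far moved this assay little. A step of a 2.3-fold lower number from compound 3 to compound 4 (0.35 log units; beyond the scatter) is expected, leaving the outcome uncertain. Compound 4 is estimated to give 15000 nM, within a range of 4000 nM to 40000 nM.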

Compound 4, solubility: 23200 nM
Compound 4: middle estimate off by 1.5-fold (0.19 log units), on the low side; the measured number falls inside the stated range.
By their numbers in this assay, from the lowest: compounds 4, 2, 1 and 3 (each within the scatter of the next).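

In this assay the five-membered aromatic ring with 3 hetero atoms stays within the scatter of every earlier group: a 1.5-fold lower number from compound 3 to compound 4 (0.16 log units; within the scatter) and a 1.4-fold lower number from compound 1 to compound 4 (0.14 log units; within the scatter) and a 1.0-fold lower number from compound 2 to compound 4 (0.01 log units; within the scatter) are all small steps. Four different groups on this saturated chain carbon now give numbers within the scatter of one another, and adding 2 oxygen atoms to the ring has not changed that picture. No measurement at hand bears on why these numbers sit so close together. As far as these compounds go, whether a primary amine or a carboxylic acid on this carbon would give a step beyond the scatter remains open.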